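The compounds below may be only part of what the source reports. "The series", "measured", "known", "first", "only" and "open" are said of these compounds alone.

Measured so far:
compound 1 `COc1cccc(-c2c(S(=O)(=O)c3cccc(C#N)c3)cnc3cc(F)ccc23)c1` — 1.83 mL/min
compound 2 `COc1cccc(-c2c(S(=O)(=O)c3cc(Cl)cc(Cl)c3)cnc3cc(F)ccc23)c1` — 1.51 mL/min
compound 3 `COc1cccc(-c2c(S(=O)(=O)c3ccc(F)c(F)c3)cnc3cc(F)ccc23)c1` — 1.77 mL/min

In an ADME assay on microsomes from liver (Homo sapiens) for metabolic stability, tested at 2.5 uM (a higher number here means faster removal of the compound, a lower number slower removal), compound 1 gives 1.83 mL/min, the highest of the three numbers, but a 1.2-fold lower number from compound 1 to compound 2 (0.08 log units; within the scatter) and a 1.0-fold lower number from compound 1 to compound 3 (0.01 log units; within the scatter) both sit within the scatter, as does a 1.2-fold higher number from compound 2 to compound 3 (0.07 log units; within the scatter). Compound 4 `N#Cc1cccc(S(=O)(=O)c2cnc3cc(F)ccc3c2-c2cccc(F)c2)c1` differs from compound 1 in one place: fluoro in place of methoxy on an aromatic carbon. Every measured step changes the group on the sulfonyl sulfur and leaves the 3-methoxyphenyl untouched, so no measured step bears directly on this change; the only guidance is that the series so far has shown no step beyond the scatter at all. For compound 4 the number in this assay is therefore estimated at 1.8 mL/min, with a range of 1 mL/min to 3.3 mL/min. This estimate amounts to an expected 1.0-fold lower number from compound 1 to compound 4 (0.01 log units; within the scatter), essentially flat.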

Compound 4, intrinsic clearance in a liver preparation (reported as CLH), per the amount of preparation that the assay uses: 0.78 mL/min
Beside the measured number, compound 4's estimate is 2.3-fold (0.36 log units) above it; the whole stated range lies above it.
By their numbers in this assay, from the lowest: compounds 4, 2, 3 and 1 (each within the scatter of the next, the first and the last beyond it).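

In this assay, fluoro in place of methoxy on an aromatic carbon gives a 2.3-fold lower number from compound 1 to compound 4 (0.37 log units; beyond the scatter), the only step shown that lies beyond the scatter. For the compounds shown here, the three compounds with the 3-methoxyphenyl group stay within the scatter of each other across their sulfonyl groups, so this position on the 3-methoxyphenyl ring is the first place where a single change registers. Nothing shown accounts for the step.

Open, on these data alone, is whether removing methoxy or adding fluoro drives the step, and how a hydroxyl or an amine at this position would read. Also open, as far as these compounds go, is whether the step holds with 3,5-dichlorophenyl or 3,4-difluorophenyl on the sulfonyl sulfur.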